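From compound 3 to compound 4, one side group exchanged

This account rests on a few compounds, and the source may have more. Where it says the series, first, only, none or still open, it means among the compounds named here.

Of the compounds shown here, three sharing one core have been measured in a functional assay on HCT-116 cells (Homo sapiens) for inhibition; on this read-out higher numbers stand for an effect only at larger amounts of compound and lower numbers for an effect already at smaller amounts. Compound 1 `COc1cc(N2CCN(C(=O)N3CCN(C)CC3)CC2)ccc1Nc1nc(NC2CCCCC2)c2nc[nH]c2n1` gives 18 nM, compound 2 `COc1cc(N2CCN(Cc3ccccn3)CC2)ccc1Nc1nc(NC2CCCCC2)c2nc[nH]c2n1` gives 89 nM, and compound 3 `COc1cc(N2CCC(CC(=O)N3CCOCC3)CC2)ccc1Nc1nc(NC2CCCCC2)c2nc[nH]c2n1` gives 70 nM. The numbers of compound 2 and compound 3 lie within the usual scatter of each other, and both are clearly higher than the number of compound 1.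

Compound 4 `COc1cc(N2CCC(C(=O)N3CC(O)C3)CC2)ccc1Nc1nc(NC2CCCCC2)c2nc[nH]c2n1` differs from compound 3 on a saturated ring carbon of a six-membered non-aromatic ring with 1 nitrogen: (3-hydroxyazetidin-1-yl)carbonyl in place of ((morpholin-4-yl)carbonyl)methyl on a saturated ring carbon.

Within the data shown here, the only measured step between two compounds that differ in one place is a 4.9-fold higher number from compound 1 to compound 2 (0.69 log units; beyond the scatter). This modest step exchanges other groups, on a ring nitrogen rather than a ring carbon, so it offers only loose guidance and no direction for this change. It does show that exchanging one group on this core can shift the number beyond the scatter. In this assay, a step no larger than the scatter remains the expectation: a 1.3-fold lower number from compound 3 to compound 4 (0.10 log units; within the scatter). The estimate for compound 4 is 55 nM, with an expected range of 18 nM to 170 nM.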

Compound 4, half-maximal effective concentration: 260 nM
The estimate for compound 4 lay 4.7-fold (0.67 log units) below the measured number; measured number outside the range, above it.
By their numbers in this assay, from the lowest: compound 1; then compounds 3 and 2 (each within the scatter of the next); then compound 4.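

In this assay the exchange of ((morpholin-4-yl)carbonyl)methyl for (3-hydroxyazetidin-1-yl)carbonyl on the saturated ring carbon gives a 3.7-fold higher number from compound 3 to compound 4 (0.57 log units; beyond the scatter), so this ring carbon, not only the ring nitrogen of the earlier step, is a place where a change of group can move the number beyond the scatter, here towards needing more compound. Among these compounds, the single step changes several things at once: a six-membered ring gives way to a four-membered one, the methyl link is gone, and a hydrogen-bond donor enters. Nothing measured here explains the shift.

The compounds shown leave open which of these differences matters. A (morpholin-4-yl)carbonyl group directly on the ring carbon, or an (azetidin-1-yl)carbonyl group without the hydroxy, would help to separate them.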